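A Second Methoxy Group on Two Related Cores

The source may hold more compounds than are shown below. What is called first, only, known or untested is meant among the compounds shown, and "the series" means these compounds.

Compound 1, `C=C(Br)C(=O)Nc1ccc(C(=O)/C=C/c2cccc(OC)c2)cc1`: 500 nM
Compound 2, `C=C(Br)C(=O)Nc1ccc(C(=O)/C=C/c2cccc(OC)c2OC)cc1`: 380 nM
Compound 3, `COc1ccccc1/C=C/C(=O)c1ccc(N)cc1`: 7800 nM

Of the compounds shown here, three have been tested in a functional assay on HeLa cells (Homo sapiens) for antiproliferative activity, with a stated time of 48 h; a lower number here means a stronger inhibitor, a higher number a weaker inhibitor. Compound 1 and compound 2 share one core and differ by a single change, (methoxy in place of hydrogen on an aromatic carbon). The step that this change made, a 1.3-fold lower number from compound 1 to compound 2 (0.12 log units; within the scatter), is too small to read as a real difference. Compound 3 stands on a different core; how the core of compound 3 differs from the core of compound 1 is not broken down here. In this assay compound 3 gives 7800 nM, the highest of the three numbers and beyond the scatter from both compound 1 and compound 2.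

Compound 4, `COc1ccc(/C=C/C(=O)c2ccc(N)cc2)c(OC)c1`, has not yet been measured. It differs from compound 3 by methoxy in place of hydrogen on an aromatic carbon. Among the compounds with values here, this is the same kind of change as the one from compound 1 to compound 2, though not the same: there the new methoxy sat ortho to a large group and ortho to a methoxy group, whereas in compound 4 it sits meta to a methoxy group and para to a large group. Within the data shown here, the only measured step of this kind is small, so a small step is also expected here, namely a 1.3-fold lower number from compound 3 to compound 4 (0.11 log units; within the scatter). On that basis compound 4 is expected to give about 6000 nM in this assay, most likely between 2500 nM and 14000 nM.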

Compound 4, half-maximal inhibitory concentration: 22000 nM
For compound 4 the middle estimate is 3.7-fold (0.56 log units) below the measured one; measured number above the stated range.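

In this assay the replacement of hydrogen by methoxy on an aromatic carbon gave a 2.8-fold higher number from compound 3 to compound 4 (0.45 log units; beyond the scatter), so on this core the added group left a weaker inhibitor. Set beside the earlier step, the same change did not bring the same result on the two cores: the same change on two cores in this assay, a 1.3-fold lower number (0.12 log units; within the scatter) from compound 1 to compound 2 and a 2.8-fold higher number (0.45 log units; beyond the scatter) from compound 3 to compound 4, 3.7-fold (0.57 log units) apart, beyond the scatter of two such steps What this does not show is that the core alone accounts for the gap: in compound 4 the new methoxy sits meta to a methoxy group and para to a large group, in compound 2 it sits at another place, and a single pair on each core cannot separate core from place.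

The compounds shown leave open whether methoxy added at the same place on both cores would give matching steps. They also leave open whether a hydroxyl group or a fluorine atom on that aromatic carbon would follow methoxy on either core.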